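The source may hold more compounds than are shown below. What is called first, only, known or untested is meant among the compounds shown, and "the series" means these compounds.

Measured in a functional assay on NCI-H460 cells (Homo sapiens) for cytotoxicity, read by MTT assay, with a stated time of 48 h; a higher number here means a weaker inhibitor, a lower number a stronger inhibitor:
Compound 1 `COc1cc(/C=C/C(=O)/C=C/c2nc3ccccc3n2C)ccc1O`: 7000 nM
Compound 2 `COc1cc(/C=C/C(=O)/C=C/c2nc3cc(C)ccc3n2C)ccc1O`: 7700 nM
Compound 3 `COc1ccc(/C=C/C(=O)/C=C/c2nc3ccccc3n2C)cc1O`: 6900 nM

Compound 3, at 6900 nM, stands within the scatter of both other compounds, so the three values cannot be told apart. Compound 4 `COc1ccc(/C=C/C(=O)/C=C/c2nc3cc(C)ccc3n2C)cc1O` is still unmeasured and carries methyl in place of hydrogen on an aromatic carbon of compound 3: methyl in place of hydrogen on an aromatic carbon. Among the measured compounds shown here, one measured step bears on this, the same replacement, a 1.1-fold higher number from compound 1 to compound 2 (0.04 log units; within the scatter). As that step stays within the scatter, no change beyond the scatter is expected in this assay, and no firm direction can be expected. The estimated change is a 1.1-fold higher number from compound 3 to compound 4 (0.04 log units; within the scatter). The estimate for compound 4 is 7500 nM, with an expected range from 4500 nM to 12000 nM.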

Compound 4, half-maximal inhibitory concentration: 7700 nM
Compound 4: the middle estimate sits 1.0-fold (0.01 log units) below what was measured; the measured number falls inside the stated range.
By their numbers in this assay, from the lowest: compounds 3, 1, 2 and 4 (each within the scatter of the next).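

In this assay, methyl in place of hydrogen on an aromatic carbon gives a 1.1-fold higher number from compound 3 to compound 4 (0.05 log units; within the scatter), so the replacement now stays within the scatter on a second core, not just on the core of compound 1. The two steps also agree with each other, and across compounds 1 to 4 this position shows no sensitivity to methyl: the same change on two cores in this assay, a 1.1-fold higher number (0.04 log units; within the scatter) from compound 1 to compound 2 and a 1.1-fold higher number (0.05 log units; within the scatter) from compound 3 to compound 4, 1.0-fold (0.01 log units) apart, within the scatter of two such steps

The compounds shown carry only hydrogen or methyl at this position. From the compounds shown here alone, whether an amine, a carboxylic acid or a longer chain there would move the number beyond the scatter remains open.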